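The source may report more compounds than this note shows. Statements on the series, on what has been measured and on what is new or still open speak of the compounds shown alone.

Two compounds with the same chlorinated, trifluoromethyl-bearing aryl group were tested in an assay on cells for inhibition of Palmitoleoyl-protein carboxylesterase NOTUM variant C330S (Homo sapiens), read by fluorescence, with a stated time of 40 min; on this read-out lower numbers stand for stronger inhibition and higher numbers for weaker inhibition. Compound 1 `Cc1cc(C(=O)O)c(C)n1-c1ccc(C(F)(F)F)c(Cl)c1` gives 1500 nM, and compound 2 `CNC(=O)C1CCN(c2ccc(Cl)c(C(F)(F)F)c2)C1` gives 1300 nM; these two numbers lie within the scatter of each other, so neither compound can be called the stronger one. Compound 3 `CN1CCN(C(=O)C2CCN(c3ccc(Cl)c(C(F)(F)F)c3)C2)CC1=O` differs from compound 2 by 4-methyl-3-oxopiperazin-1-yl in place of methylamino on a carbonyl carbon. Among the compounds with values here, no measured step of this kind is available, so the expectation for this change is none beyond the scatter, with a slight lean toward a higher number. Compound 3 is expected at 1800 nM, in the range 600 nM to 6000 nM, a step of a 1.4-fold higher number from compound 2 to compound 3 (0.14 log units; within the scatter).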

Compound 3, half-maximal inhibitory concentration: 3100 nM
The estimate for compound 3 lay 1.7-fold (0.24 log units) below the measured number; measured number inside the range.
By their numbers in this assay, from the lowest: compounds 2 and 1 (each within the scatter of the next); then compound 3.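

On a carbonyl carbon, 4-methyl-3-oxopiperazin-1-yl in place of methylamino gives a 2.4-fold higher number from compound 2 to compound 3 (0.38 log units; beyond the scatter) in this assay, a modest but real loss of inhibition at this position. The exchange brings in a six-membered ring and removes the hydrogen-bond donor of methylamino, and this single step cannot separate those two differences. No measurement shown here accounts for the step.

Still open, as far as these compounds go, is how a smaller group on the same carbonyl carbon, such as dimethylamino, would compare, keeping no donor but adding no ring. Morpholin-4-yl would similarly test a ring without the methyl-bearing lactam.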